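Chloro to methoxy on the benzyl arm of compound 1

The source may hold more compounds than are shown below. What is called first, only, known or untested is meant among the compounds shown, and "the series" means these compounds.

Of the compounds shown here, three sharing a piperazine dithiocarbamate core have been measured in a functional assay on MCF7 cells (Homo sapiens) for inhibition, read by MTT assay, with a stated time of 72 h; on this read-out higher numbers stand for weaker inhibition and lower numbers for stronger inhibition. Compound 1, `CC(C)(C)OC(=O)N1CCN(C(=S)SCc2cn(Cc3ccc(Cl)cc3)nn2)CC1`, gives 2960 nM in this assay, the lowest of the three numbers. Compound 2, `CC(C)(C)OC(=O)N1CCN(C(=S)SCc2cn(Cc3cc(=O)oc4cc(O)ccc34)nn2)CC1`, gives 10400 nM in this assay, and compound 3, `O=C(OCc1ccccc1)N1CCN(C(=S)SCc2cn(Cc3ccc(Cl)c(Cl)c3)nn2)CC1`, gives 10600 nM in this assay; both of these stand beyond the scatter from compound 1, so compound 1 is the strongest inhibitor among the three measured compounds. Compound 2 and compound 3 themselves lie within the scatter of each other, so no order between them can be stated.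

The next compound, compound 4, `COc1ccc(Cn2cc(CSC(=S)N3CCN(C(=O)OC(C)(C)C)CC3)nn2)cc1`, differs from compound 1 in one place: methoxy in place of chloro on an aromatic carbon. Among the compounds with values here, no measured pair in this set shows the effect of that particular change, so the expectation rests on compound 1 alone.

Within the data shown here, with no comparable step available, the author expects only a modest shift, likely toward a somewhat higher number, and the step from compound 1 to compound 4 is estimated at a 1.5-fold higher number from compound 1 to compound 4 (0.18 log units; within the scatter), a change that may well sit within the scatter. For compound 4 in this assay the estimated value is 4500 nM, with a range from 1500 nM to 13000 nM.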

Compound 4, half-maximal inhibitory concentration: 4960 nM
Estimate against measurement, compound 4: 1.1-fold (0.04 log units) below; low and high end bracket the measured number.
By their numbers in this assay, from the lowest: compounds 1 and 4 (each within the scatter of the next); then compounds 2 and 3 (each within the scatter of the next).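

In this assay, within the data shown here, the swap of chloro for methoxy on the aromatic carbon para to a large group gives a 1.7-fold higher number from compound 1 to compound 4 (0.22 log units; within the scatter), the first step in this set that isolates a single change. Turning the 4-chlorobenzyl arm into a 4-methoxybenzyl arm therefore leaves the read-out indistinguishable, so this position accepts methoxy, which has more heavy atoms than chloro and a hydrogen-bond acceptor where chloro has none, and the chloro group is not needed here to keep a number of this size. Nothing available speaks to why the two groups read alike, and this single pair gives no basis for explaining it.

What the compounds shown leave open is how far this tolerance extends: whether an amine, a carboxylic acid, a hydroxyl group or a longer chain such as butoxy at the same carbon would also stay within the scatter of compound 1, or whether a plain hydrogen there would. On these data alone, it also remains open whether chloro to methoxy gives a similar step when the tert-butyl carbamate of compound 1 is replaced by another group.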